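From isopropyl to a larger group on the ring nitrogen

The compounds below may be only part of what the source reports. "The series", "measured", "known", "first", "only" and "open" are said of these compounds alone.

Compound 1 `CCN1CCc2c(sc(NC=O)c2C(N)=O)C1` gives only a limit in a functional assay (strain AB) with Danio rerio as the target, read by microscopy, with a stated time of 1 h (on this read-out lower numbers stand for an effect already at smaller amounts and higher numbers for an effect only at larger amounts of compound), > 25000 nM. In this assay compound 2 `CC(C)(C)OC(=O)CCC[N+]1(C)CCc2c(sc(NC(=O)Nc3ccc(Cl)cc3)c2C(N)=O)C1` gives 250 nM and compound 3 `CC(C)[N+]1(C)CCc2c(sc(NC(=O)Nc3ccc(Cl)cc3)c2C(N)=O)C1` gives 960 nM, the higher of the two actual numbers. Compound 4 `CC(C)(C)OC(=O)CCCCC[N+]1(C)CCc2c(sc(NC(=O)Nc3ccc(Cl)cc3)c2C(N)=O)C1` differs from compound 3 on an amine nitrogen in a ring: a group of 12 heavy atoms (10 carbon, 2 oxygen; no ring) in place of a group of 3 heavy atoms (3 carbon; no ring), on an amine nitrogen in a ring. Within the data shown here, one measured step bears on this change: a 3.8-fold higher number from compound 2 to compound 3 (0.58 log units; beyond the scatter), where isopropyl took the place of 3-(tert-butoxycarbonyl)propyl at that same nitrogen. That step was modest but beyond the scatter. Compound 4 runs the other way, giving up isopropyl for a larger group, though not the group carried by compound 2. The data hold no measured comparison of different chain lengths, so the expectation rests on that single step, read in reverse, and stays loose. A lower number of similar size is expected in this assay, with the estimated move being a 3.2-fold lower number from compound 3 to compound 4 (0.51 log units; beyond the scatter). The estimate for compound 4 is 300 nM, with an expected range from 90 nM to 1000 nM.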

Compound 4, half-maximal effective concentration: 110 nM
Estimate against measurement, compound 4: 2.7-fold (0.44 log units) above; measured number inside the range.
By their numbers in this assay, from the lowest: compound 4; then compound 2; then compound 3. At a limit, above all of these: compound 1.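

In this assay, among these compounds, the larger group on the amine nitrogen in a ring gives a bigger move than the single step known before, with an 8.7-fold lower number from compound 3 to compound 4 (0.94 log units; beyond the scatter) as the result of replacing isopropyl. The position also responds to the length of the chain while the tert-butyl ester at its end stays in place, and a 2.3-fold lower number from compound 2 to compound 4 (0.36 log units; beyond the scatter) gives the first such comparison, which is smaller but still beyond the scatter. No measurement shown accounts for either step.

Two chain lengths cannot show how far this direction continues, so a longer chain remains an open case. Nor do the compounds separate the chain from the ester, which a plain alkyl chain or a carboxylic acid at the chain end would address.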